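Urea to amide at the distal aryl of compound 3

This account rests on a few compounds, and the source may have more. Where it says the series, first, only, none or still open, it means among the compounds named here.

On a functional assay on HCT-15 cells (Homo sapiens) for inhibition, read by sulforhodamine B assay, with a stated time of 48 h, tested at 0.01 uM (a higher number here means a weaker effect of the compound at the concentration tested, a lower number a stronger effect), the series reads: compound 1 `O=C(Nc1cccc(-n2cc(-c3ccncc3)c(-c3cc(O)cc(Cl)c3)n2)c1)Nc1ccc(Cl)c(C(F)(F)F)c1` gives 93%, compound 2 `O=C(Nc1cccc(-n2cc(-c3ccncc3)c(-c3cc(O)cc(Cl)c3)n2)c1)Nc1ccc(Cl)c(Cl)c1` gives 59% and compound 3 `COc1cc(Cl)cc(-c2nn(-c3cccc(NC(=O)Nc4ccc(Cl)c(Cl)c4)c3)cc2-c2ccncc2)c1` gives 93%. Compound 3 stands level with compound 1 at the digits printed, the two together the highest of the three, and sits a number 34 percentage points higher from compound 2 to compound 3 (beyond the scatter). Among the compounds with values here, compound 4 `COc1cc(Cl)cc(-c2nn(-c3cccc(NC(=O)c4cccc(C(F)(F)F)c4)c3)cc2-c2ccncc2)c1` differs from compound 3 in one place: 3-(trifluoromethyl)phenyl in place of (3,4-dichlorophenyl)amino on a carbonyl carbon No measured step removes the amide-type nitrogen, so the only bearing is indirect: a number 34 percentage points lower from compound 1 to compound 2 (beyond the scatter) shows that changing the distal aryl can move this assay strongly. For compound 4 a step of a number 3 percentage points lower from compound 3 to compound 4 (within the scatter) is expected, essentially none beyond the scatter, since both compounds carrying a trifluoromethyl or methoxy change sat high. Compound 4 is estimated at 90%, between 70% and 102%.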

Compound 4, a percentage reported as activity, at one concentration (the size of the read-out at that concentration, not a potency): 56%
Compound 4: the middle estimate sits 34 percentage points above what was measured; measured number below the stated range.
By their numbers in this assay, from the lowest: compounds 4 and 2 (each within the scatter of the next); then compounds 1 and 3 (each within the scatter of the next).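

In this assay, a number 37 percentage points lower from compound 3 to compound 4 (beyond the scatter), so the high reading of compound 3 can be lowered by a change on the carbonyl carbon alone, with the methoxy group kept. This single change removes the amide-type nitrogen and its hydrogen-bond donor and also exchanges the two chlorines for trifluoromethyl, so the two parts cannot be told apart. No measured evidence accounts for the step.

Open, on these data alone, is whether the nitrogen or the aryl substitution carries the step. Also open, as far as these compounds go, is how this position would respond to a carboxylic acid or an amine on the distal aryl.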